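A few compounds are considered here, and "the series" means these few. Any claim that something is new, unique, unknown or untested is made for them only; others in the source may bear on it.

Within the data shown here, in a functional assay (strain AB) with Danio rerio as the target, read by microscopy, with a stated time of 1 h (a lower number here means that less compound is needed, a higher number that more compound is needed for the effect), compound 3 `CCN1CCc2c(sc(NC(=O)Nc3ccc(Cl)cc3)c2C(N)=O)C1` gives 3120 nM and holds the only true number so far. Compound 1 `CCN1CCc2c(sc(NC(=O)Nc3ccccc3)c2C(N)=O)C1` gives > 25000 nM as a limit of the assay. Compound 2 `CCN1CCc2c(sc(NC=O)c2C(N)=O)C1` gives > 25000 nM as a limit too. The two readable steps are an at least 8.0-fold lower number from compound 1 to compound 3 (0.90 log units; beyond the scatter) and an at least 8.0-fold lower number from compound 2 to compound 3 (0.90 log units; beyond the scatter) and neither alters the ethyl group on the amine nitrogen in a ring.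

Compound 4 `CN1CCc2c(sc(NC(=O)Nc3ccc(Cl)cc3)c2C(N)=O)C1` differs from compound 3 only there: hydrogen in place of methyl on a saturated chain carbon bound to an amine nitrogen in a ring with ethyl shortened to methyl. Among the measured compounds shown here, no measured step tests this change, so no step beyond the scatter is expected in this assay. Compound 4 keeps the chloro gained in an at least 8.0-fold lower number from compound 1 to compound 3 (0.90 log units; beyond the scatter) and is therefore expected to stay close to compound 3. The expected step is a 1.1-fold higher number from compound 3 to compound 4 (0.05 log units; within the scatter) and remains only an estimate. For compound 4 the estimated value is 3500 nM with an expected range of 1000 nM to 12000 nM in this estimate.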

Compound 4, half-maximal effective concentration: 4700 nM
Compound 4: middle estimate off by 1.3-fold (0.13 log units), on the low side, within the range that was stated.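

In this assay, shortening ethyl to methyl on the amine nitrogen in a ring gives a 1.5-fold higher number from compound 3 to compound 4 (0.18 log units; within the scatter). Among these compounds, the earlier compounds all carried ethyl there, so this is the first sign that this group can change without a step beyond the scatter, at least for this one small change with the chloro kept. No measurement shown bears on a cause for this step. On these data alone, how a longer chain such as propyl, or a bulkier group such as benzyl, would behave on that nitrogen stays open. As far as these compounds go, a carboxylic acid at the end of such a chain also stays open.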